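Hydroxy to methoxy on the shared core: expected cytotoxicity

The source may report more compounds than this note shows. Statements on the series, on what has been measured and on what is new or still open speak of the compounds shown alone.

Compound 1 `O=C(/C=C/c1ccc(OCCCCO[N+](=O)[O-])c(O)c1)OCCCCO[N+](=O)[O-]` is the starting point of the step followed here. In a functional assay on NCI-H1792 cells (Homo sapiens) for cytotoxicity, read by resazurin assay, with a stated time of 72 h (a higher number here means a weaker inhibitor, a lower number a stronger inhibitor), compound 1 gives > 50000 nM, which is a limit of the assay and not a number. Compound 2 `COc1cc(/C=C/C(=O)Oc2cccc(OCc3c(-c4ccccc4)no[n+]3[O-])c2)ccc1O` belongs to the same set. In this assay compound 2 gives > 50000 nM, again a limit rather than a measured value. Going by the values given here, the whole picture so far is the limit of > 50000 nM in this assay, at which 2 of the 2 values shown sit, so no measured step between compounds exists and no direction of change can be read from the numbers. Compound 3 `COc1cc(/C=C/C(=O)OCCCCO[N+](=O)[O-])ccc1OCCCCO[N+](=O)[O-]` is the compound not yet measured; it differs from compound 1 by methyl in place of hydrogen on an oxygen on an aromatic ring, a change with no ring, no hydrogen-bond donors or acceptors and no net charge. With both known values sitting at the limit, no change beyond the scatter is expected for this step, in either direction. The estimated step is a step that the limit leaves unreadable from compound 1 to compound 3. Compound 3 is expected to give about 60000 nM in this assay, with an estimated range from 25000 nM to 150000 nM, and is most likely to be reported as a limit once more.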

Compound 3, half-maximal inhibitory concentration: > 50000 nM
Compound 3 was reported as a limit; the forecaster's own chance of this, stated with the estimate: 80%; the middle value lies beyond the limit too.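

In this assay compound 3 gives > 50000 nM, a limit of the assay and not a number. The step from compound 1 to compound 3 cannot be read, and no comparison is possible: the limit of > 50000 nM in this assay, at which 3 of the 3 values shown sit.

The compounds shown leave open whether hydroxy to methoxy on the shared core changes cytotoxicity at all.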